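Side-chain changes on the shared core, tail flick read-out

The source may hold more compounds than are shown below. What is called first, only, known or untested is meant among the compounds shown, and "the series" means these compounds.

Measured in a functional assay on the whole organism (Tail, strain ICR) with Mus musculus as the target, in the tail flick test, with a stated time of 150 min, at a dose of 25 umol/kg by the oral route; on this read-out lower numbers stand for a weaker effect and higher numbers for a stronger effect at the one dose given:
compound 1 `O=C(CN(c1ncnc2c1ncn2C1CCCCO1)C1CC1)N[C@@H](CO)C(=O)OCc1ccccc1` gives 18.3%
compound 2 `N=C(N)NCCC[C@H](NC(=O)CN(c1nc(Cl)nc2[nH]cnc12)C1CC1)C(=O)OCc1ccccc1` gives 6.12%
compound 3 `NCCCC[C@H](NC(=O)CN(c1nc(Cl)nc2[nH]cnc12)C1CC1)C(=O)OCc1ccccc1` gives 9.88%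

Compound 1 stands beyond the scatter above compound 2; compound 3 sits within the scatter of compound 1. Within the data shown here, the only single-place step recorded, a number 3.8 percentage points higher from compound 2 to compound 3 (within the scatter), concerns a different core and a different chain position. Compound 4 `NC(=O)CC[C@H](NC(=O)CN(c1ncnc2c1ncn2C1CCCCO1)C1CC1)C(=O)OCc1ccccc1` differs from compound 1 by carbamoylmethyl in place of hydroxy on a saturated chain carbon, two bonds along the chain from an amide-type nitrogen and a carbonyl carbon. Among the measured compounds shown here, no measured step shares this core with a change at this place, so nothing measured supports a shift beyond the scatter in this assay . Compound 4 is therefore expected near compound 1, with a number 2.3 percentage points lower from compound 1 to compound 4 (within the scatter) as the estimated step. For compound 4 the estimate is 16%, in the range 5% to 30%.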

Compound 4, a percentage reported as activity, at one dose (the size of the read-out at that dose, not a potency): 10.7%
The estimate for compound 4 lay 5.3 percentage points above the measured number, within the range that was stated.
By their numbers in this assay, from the lowest: compounds 2, 3, 4 and 1 (each within the scatter of the next, the first and the last beyond it).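

In this assay, carbamoylmethyl in place of hydroxy on a saturated chain carbon, two bonds along the chain from an amide-type nitrogen and a carbonyl carbon, gives a number 7.6 percentage points lower from compound 1 to compound 4 (within the scatter). Among these compounds, this is the first step read at this place on the core of compound 1, and at the one dose given, the exchange does not move the read-out beyond the scatter. Nothing measured here bears on the reason for this result.

From the compounds shown here alone, whether an amine, a carboxylic acid or a chain longer than 2-carbamoylethyl at this place would stay within the scatter of compound 1 remains open.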